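Para-substituent swaps on the benzyl ether of the sulfonanilide

The source may hold more compounds than are shown below. What is called first, only, known or untested is meant among the compounds shown, and "the series" means these compounds.

Compound 1 `CS(=O)(=O)Nc1ccc([N+](=O)[O-])cc1OCc1ccc([N+](=O)[O-])cc1` sets the reference point: in an assay on SK-BR-3 cells for inhibition of Aromatase (Homo sapiens) (a higher number here means a weaker inhibitor, a lower number a stronger inhibitor), compound 1 gives 400 nM, the lowest of the three numbers recorded. Compound 2 `CS(=O)(=O)Nc1ccc([N+](=O)[O-])cc1OCc1ccc2ccccc2c1` keeps the same core but carries a naphthylmethyl ether; in this assay compound 2 gives 2170 nM. Compound 3 `CC(C)c1ccc(COc2cc([N+](=O)[O-])ccc2NS(C)(=O)=O)cc1` is the direct one-place analogue; in this assay compound 3 gives 7450 nM.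

Compound 4 `CS(=O)(=O)Nc1ccc([N+](=O)[O-])cc1OCc1ccc(Cl)cc1` is not yet measured. It differs from compound 1 by chloro in place of nitro on an aromatic carbon. Going by the values given here, the only measured step that touches this position is a 19-fold higher number from compound 1 to compound 3 (1.27 log units; beyond the scatter), and the pair compound 1 and compound 2 shows a weaker number when the ring is altered too. Both point the same way: departing from the nitro at this carbon has so far cost potency, and the isopropyl swap was large. Chloro is a single heavy atom with no acceptors, so a smaller loss than that of compound 3 is expected. For compound 4 the step is estimated at roughly a 4.0-fold higher number from compound 1 to compound 4 (0.60 log units; beyond the scatter). Compound 4 is therefore estimated at 1600 nM, with a plausible range from 500 nM to 5000 nM.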

Compound 4, half-maximal inhibitory concentration: 290 nM
Estimate against measurement, compound 4: 5.5-fold (0.74 log units) above, and the stated range ends above it.
By their numbers in this assay, from the lowest: compounds 4 and 1 (each within the scatter of the next); then compound 2; then compound 3.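

In this assay the nitro on this aromatic carbon proves not to be needed: chloro, which has no hydrogen-bond acceptors, takes its place with no change beyond the scatter (a 1.4-fold lower number from compound 1 to compound 4 (0.14 log units; within the scatter)). The large loss seen with isopropyl therefore does not follow from removing nitro as such, since chloro on the same carbon gives a much lower number (a 26-fold lower number from compound 3 to compound 4 (1.41 log units; beyond the scatter)). Nothing measured here offers a reason for either step.

Going by these compounds, whether other groups on this carbon, such as fluoro, bromo, methoxy, an amine or a carboxylic acid, stay level with chloro and nitro or fall towards isopropyl remains open. On these data alone, the rest of the shared core is the same in all four compounds, so what changes there would do is also open.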